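Nitro for chloro in the acetylated series

The compounds below may be only part of what the source reports. "The series", "measured", "known", "first", "only" and "open" are said of these compounds alone.

Compound 1 `COc1ccc(C2CC(Nc3nc4ccc([N+](=O)[O-])cc4s3)=NN2C(C)=O)cc1`: 145 umol/kg
Compound 2 `CC(=O)N1N=C(Nc2nc3ccccc3s2)CC1OC1=CC=C1`: 382 umol/kg
Compound 3 `CC(=O)N1N=C(Nc2nc3ccc(Cl)cc3s2)CC1OC1=CC=C1`: 212 umol/kg

In a functional assay on the whole organism (Hindlimb, strain albino) with Mus musculus as the target, in the maximal electroshock model, with a stated time of 0.5 h (a lower number here means that less compound is needed, a higher number that more compound is needed for the effect), compound 3 gives 212 umol/kg, within the scatter of both compound 1 and compound 2. The next compound, compound 4 `CC(=O)N1N=C(Nc2nc3ccc([N+](=O)[O-])cc3s2)CC1OC1=CC=C1`, differs by nitro in place of chloro on an aromatic carbon. Going by the values given here, the only measured step at this place is a 1.8-fold lower number from compound 2 to compound 3 (0.26 log units; within the scatter), chloro in place of hydrogen. Compound 1 also carries a nitro group and gives 145 umol/kg, but it differs elsewhere in the structure. No step beyond the scatter is therefore expected. The expected step is a 1.1-fold lower number from compound 3 to compound 4 (0.05 log units; within the scatter). Compound 4 is estimated at 190 umol/kg, with an expected range of 95 umol/kg to 380 umol/kg.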

Compound 4, dose for half-maximal effect: 274 umol/kg
The estimate for compound 4 lay 1.4-fold (0.16 log units) below the measured number; the range from low to high includes it.
By their numbers in this assay, from the lowest: compounds 1, 3, 4 and 2 (each within the scatter of the next, the first and the last beyond it).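

In this assay, with a 1.3-fold higher number from compound 3 to compound 4 (0.11 log units; within the scatter) and a 1.4-fold lower number from compound 2 to compound 4 (0.14 log units; within the scatter) as the steps, hydrogen, chloro and nitro on this aromatic carbon cannot be told apart. With nitro held fixed, a 1.9-fold higher number from compound 1 to compound 4 (0.28 log units; within the scatter) is the step for the exchange on the saturated ring carbon, and it also stays within the scatter. No evidence on the cause of these steps is available.
From the compounds shown here alone, whether an amine or a carboxylic acid on this aromatic carbon would give a step beyond the scatter remains open. Also open, going by these compounds, is whether a longer chain on the saturated ring carbon would do so.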